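The source may hold more compounds than are shown below. What is called first, only, known or untested is meant among the compounds shown, and "the series" means these compounds.

The measured compounds are:

compound 1, `Cc1ccc(S(=O)(=O)Nc2nnc(SCc3ccccc3)s2)cc1`, giving 65% in a toxicity assay on HaCaT cells (Homo sapiens) for cytotoxicity, tested at 250 uM; a lower number here means a stronger effect, a higher number a weaker effect of the compound at the concentration tested;
compound 2, `Cc1ccc(S(=O)(=O)Nc2nnc(SCc3ccc(Cl)cc3)s2)cc1`, giving 70% in this assay;
compound 3, `Cc1cc(C)c(S(=O)(=O)Nc2nnc(SCc3ccccc3)s2)c(C)c1`, giving 52% in this assay.

Compound 1 and compound 2 share one core, and compound 2 differs from compound 1 only by chloro in place of hydrogen on an aromatic carbon. This change made the step of a number 5 percentage points higher from compound 1 to compound 2 (within the scatter), so the two values cannot be told apart. Compound 3 rests on another core; the difference between the cores of compound 1 and compound 3 is not broken down here. Compound 3 gives the lowest number of the three, with both other values beyond the scatter above it.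

Compound 4, `Cc1cc(C)c(S(=O)(=O)Nc2nnc(SCc3ccc(Cl)cc3)s2)c(C)c1`, is not yet measured. Among the compounds with values here, it differs from compound 3 by chloro in place of hydrogen on an aromatic carbon, which is the same change as the one from compound 1 to compound 2, at the same kind of place. The step of a number 3 percentage points higher from compound 3 to compound 4 (within the scatter) is therefore expected to be small, because the matching step a number 5 percentage points higher from compound 1 to compound 2 (within the scatter) stayed within the scatter. Compound 4 is estimated at 55%, with a range from 42% to 68%.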

Compound 4, a percentage reported as activity, at one concentration (the size of the read-out at that concentration, not a potency): 66%
Estimate against measurement, compound 4: 11 percentage points below, within the range that was stated.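

In this assay, chloro in place of hydrogen on the core of compound 3 made the step of a number 14 percentage points higher from compound 3 to compound 4 (beyond the scatter), and set against the earlier step on the core of compound 1, the two steps cannot be told apart: the same change on two cores in this assay, a number 5 percentage points higher (within the scatter) from compound 1 to compound 2 and a number 14 percentage points higher (beyond the scatter) from compound 3 to compound 4, 9 percentage points apart, within the scatter of two such steps. The change can thus be read as carrying over from one core to the other, with no measurable dependence on the core, but this does not show that the step has the same size on both, and two pairs set no rule for other cores. With the chloro in place, 2,4,6-trimethylphenyl in place of 4-methylphenyl on the sulfonyl sulfur made the step of a number 4 percentage points lower from compound 2 to compound 4 (within the scatter), so these two compounds cannot be told apart either.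

Left open is how a fluoro, a methoxy or a carboxylic acid in place of the chloro, or a longer chain in place of the benzyl, would read in this assay. Also open, as far as these compounds go, is whether the chloro step holds on any further core.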